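The source may hold more compounds than are shown below. What is called first, only, known or untested is meant among the compounds shown, and "the series" means these compounds.

Compound 1 `CCCOc1cc([N+](=O)[O-])ccc1N(C)S(C)(=O)=O` gives 760 nM in an assay on SK-BR-3 cells for inhibition of Aromatase (Homo sapiens); on this read-out higher numbers stand for weaker inhibition and lower numbers for stronger inhibition. Compound 2 `CC(C)Oc1cc([N+](=O)[O-])ccc1N(C)S(C)(=O)=O` gives 2810 nM in this assay, and compound 3 `CN(c1ccc([N+](=O)[O-])cc1OCC1CCCCC1)S(C)(=O)=O` gives 960 nM. Compound 3 therefore sits second highest of the three numbers: its nearest neighbour is compound 1, with a 1.3-fold higher number from compound 1 to compound 3 (0.10 log units; within the scatter) within the scatter, while compound 2 lies furthest, with a 2.9-fold lower number from compound 2 to compound 3 (0.47 log units; beyond the scatter). Compound 4 `CN(c1ccc([N+](=O)[O-])cc1OC1CCCC1)S(C)(=O)=O` carries cyclopentyl in place of cyclohexylmethyl on an oxygen on an aromatic ring. Within the data shown here, two steps bear on this change: a 3.7-fold higher number from compound 1 to compound 2 (0.57 log units; beyond the scatter), and a 2.9-fold lower number from compound 2 to compound 3 (0.47 log units; beyond the scatter). Both are modest, and the cyclopentyl of compound 4 resembles the isopropyl of compound 2 as much as the ring of compound 3, so a small rise in this assay is expected, a 1.6-fold higher number from compound 3 to compound 4 (0.19 log units; within the scatter). Compound 4 is estimated at 1500 nM, with a range of 500 nM to 4500 nM.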

Compound 4, half-maximal inhibitory concentration: 440 nM
Beside the measured number, compound 4's estimate is 3.4-fold (0.53 log units) above it, outside the stated range (below it).
By their numbers in this assay, from the lowest: compounds 4, 1 and 3 (each within the scatter of the next, the first and the last beyond it); then compound 2.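

On an oxygen on an aromatic ring, cyclopentyl separates clearly from isopropyl (a 6.4-fold lower number from compound 2 to compound 4 (0.81 log units; beyond the scatter)), so the isopropyl value does not carry over to this ring. Cyclopentyl also separates from cyclohexylmethyl (a 2.2-fold lower number from compound 3 to compound 4 (0.34 log units; beyond the scatter)), while it cannot be told apart from propyl (a 1.7-fold lower number from compound 1 to compound 4 (0.24 log units; within the scatter)). Nothing available here accounts for these differences.

Open, as far as these compounds go, is whether cyclobutyl or cyclohexyl directly on this oxygen would match cyclopentyl. Also open, from the compounds shown here alone, is how a longer chain or a chain ending in an amine would read in this assay.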